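One added methyl on the outer aromatic ring

A few compounds are considered here, and "the series" means these few. Any claim that something is new, unique, unknown or untested is made for them only; others in the source may bear on it.

Measured compounds:
compound 1 `CC(C(=O)NCc1ccc(C(F)(F)F)cc1N1CCN(C2CCCCC2)CC1)c1ccc(NS(C)(=O)=O)c(F)c1` — 13.8 nM
compound 2 `CC(C(=O)NCc1ccc(C(F)(F)F)cc1N1CCN(c2ccccc2)CC1)c1ccc(NS(C)(=O)=O)c(F)c1` — 2 nM

In an assay on CHO cells for antagonist activity at transient receptor potential cation channel subfamily V member 1 (Homo sapiens), read by FLIPR (on this read-out lower numbers stand for stronger inhibition and higher numbers for weaker inhibition), compound 1 gives 13.8 nM and compound 2 gives 2 nM. Among the measured compounds shown here, the only measured step, a 6.9-fold lower number from compound 1 to compound 2 (0.84 log units; beyond the scatter), leaves compound 2 with the lowest number of the two. Compound 3 `Cc1ccc(N2CCN(c3cc(C(F)(F)F)ccc3CNC(=O)C(C)c3ccc(NS(C)(=O)=O)c(F)c3)CC2)cc1` differs from compound 2 by methyl in place of hydrogen on an aromatic carbon. For the measured compounds named here, no measured step touches this position, and the step from cyclohexyl to phenyl bears on a different part of the molecule, so the expectation rests on compound 2 alone. Compound 3 is expected to sit close to compound 2, with a 1.3-fold higher number from compound 2 to compound 3 (0.10 log units; within the scatter), a step not beyond the scatter; the estimate for compound 3 is 2.5 nM, between 0.8 nM and 8 nM.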

Compound 3, inhibition constant: 0.7 nM
Beside the measured number, compound 3's estimate is 3.6-fold (0.55 log units) above it; measured number below the stated range.
By their numbers in this assay, from the lowest: compound 3; then compound 2; then compound 1.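

In this assay, the position para to a large group on the outer aromatic ring turns out to respond to substitution: methyl in place of hydrogen gives a 2.9-fold lower number from compound 2 to compound 3 (0.46 log units; beyond the scatter). Phenyl to 4-methylphenyl therefore extends the earlier ring change, and 4-methylphenyl in place of cyclohexyl gives a 20-fold lower number from compound 1 to compound 3 (1.29 log units; beyond the scatter). No measurement available here accounts for the effect of this methyl. As far as these compounds go, whether the same carbon would respond likewise to ethyl, methoxy or chlorine stays open. So does whether methyl on another carbon of this ring would have a similar effect.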